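Hydroxy on the naphthalen-2-yl amide: expected shift

The source may report more compounds than this note shows. Statements on the series, on what has been measured and on what is new or still open speak of the compounds shown alone.

Working notes on the shared core. Three analogues have numbers. Compound 1 `CC(C)(CNC(=O)c1ccccc1)CC1=C(O)C(=O)c2ccccc2C1=O` gives 15200 nM in a functional assay on KB cells (Homo sapiens) for cytotoxicity, read by resazurin assay, with a stated time of 3 days; a higher number here means a weaker inhibitor, a lower number a stronger inhibitor. Compound 2 `CC(C)(CNC(=O)c1ccccc1O)CC1=C(O)C(=O)c2ccccc2C1=O` gives 44900 nM in this assay. Compound 3 `CC(C)(CNC(=O)c1ccc2ccccc2c1)CC1=C(O)C(=O)c2ccccc2C1=O` gives 9000 nM in this assay, the lowest of the three numbers: its nearest neighbour is compound 1, with a 1.7-fold lower number from compound 1 to compound 3 (0.23 log units; within the scatter), within the scatter, and its furthest is compound 2, with a 5.0-fold lower number from compound 2 to compound 3 (0.70 log units; beyond the scatter), beyond the scatter. The gap to compound 1 lies within the scatter. No order between compound 3 and compound 1 is claimed.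

Compound 4 `CC(C)(CNC(=O)c1ccc2ccccc2c1O)CC1=C(O)C(=O)c2ccccc2C1=O` has not yet been measured. Against compound 3 the change is hydroxy in place of hydrogen on an aromatic carbon. The measured step that bears on it is a 3.0-fold higher number from compound 1 to compound 2 (0.47 log units; beyond the scatter), the same hydroxy in place of hydrogen on an aromatic carbon, there on the phenyl. On that single precedent compound 4 is expected to give a higher number than compound 3 in this assay, an expected step of a 3.0-fold higher number from compound 3 to compound 4 (0.48 log units; beyond the scatter). The estimate for compound 4 in this assay is 27000 nM, with a range of 9000 nM to 81000 nM. With one precedent only, the range is kept wide.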

Compound 4, half-maximal inhibitory concentration: 26900 nM
Beside the measured number, compound 4's estimate is 1.0-fold (0.00 log units) above it, and the stated range covers the measured number.
By their numbers in this assay, from the lowest: compounds 3, 1, 4 and 2 (each within the scatter of the next, the first and the last beyond it).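

On the naphthalen-2-yl amide, hydroxy in place of hydrogen on an aromatic carbon, ortho to a fused ring and ortho to a large group, gives a 3.0-fold higher number from compound 3 to compound 4 (0.48 log units; beyond the scatter) in this assay, so the shift seen on the phenyl amide is not confined to that single ring. Within these two matched pairs the size of the step carries over from the phenyl amide to the fused two-ring system, with no compound shown going against it: the same change on two cores in this assay, a 3.0-fold higher number (0.47 log units; beyond the scatter) from compound 1 to compound 2 and a 3.0-fold higher number (0.48 log units; beyond the scatter) from compound 3 to compound 4, 1.0-fold (0.01 log units) apart, within the scatter of two such steps. The hydroxy step therefore now rests on two separate pairs rather than on one, and in both pairs the compound bearing hydroxy gives the higher number.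

The compounds shown leave open whether the higher number follows hydroxy specifically or any replacement of hydrogen on this aromatic carbon, a question that methoxy, an amine or a carboxylic acid in the same place would address. Also open, on these data alone, is whether hydroxy on another aromatic carbon of the same ring gives a step of similar size, or whether the step depends on this place.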